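Alkynyl alcohols in the series: expected cytotoxicity of compound 4

The compounds below may be only part of what the source reports. "The series", "measured", "known", "first", "only" and "open" are said of these compounds alone.

compound 1 `O=[N+]([O-])c1c(CS(=O)(=O)c2ccccc2)nc2c(C#CCO)cc(Cl)cn12`: 10100 nM
compound 2 `CC(O)C#Cc1cc(Cl)cn2c([N+](=O)[O-])c(CS(=O)(=O)c3ccccc3)nc12`: 44200 nM
compound 3 `CCC(O)CC#Cc1cc(Cl)cn2c([N+](=O)[O-])c(CS(=O)(=O)c3ccccc3)nc12`: > 62500 nM (a limit)

All three results come from an ADME assay on HepG2 cells (Homo sapiens) for cytotoxicity, read by MTT assay, with a stated time of 72 h; on this read-out higher numbers stand for lower toxicity in this test and lower numbers for higher toxicity in this test. Compound 3 gives no number, only a limit of the assay: > 62500 nM.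

The next structure is compound 4 `O=[N+]([O-])c1c(CS(=O)(=O)c2ccccc2)nc2c(C#CC3(O)CCCCC3)cc(Cl)cn12`. The change is 1-hydroxycyclohexyl in place of 2-hydroxybutyl on a triple-bonded carbon, with 1-hydroxycyclohexyl in place of 2-hydroxybutyl on a triple-bonded carbon.

Among the compounds with values here, three measured steps bear on this change. Two are modest: a 4.4-fold higher number from compound 1 to compound 2 (0.64 log units; beyond the scatter), and an at least 6.1-fold higher number from compound 1 to compound 3 (0.79 log units; beyond the scatter). The third, an at least 1.4-fold higher number from compound 2 to compound 3 (0.15 log units; that floor lies within the scatter), has a floor within the scatter and so fixes no order. Among these three compounds, the larger groups on the triple-bonded carbon go with higher numbers than compound 1, and no compound goes against this. Within the data shown here, the limit on compound 3 leaves its true position open, so no firm step can be derived from it.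

No step beyond the scatter is expected in this assay, and the estimate is an at least 1.2-fold lower number from compound 3 to compound 4 (0.09 log units; that floor lies within the scatter). For compound 4 the estimated value is 50000 nM, with an expected range of 18000 nM to 90000 nM.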

Compound 4, half-maximal cytotoxic concentration: > 25000 nM
Compound 4: only a limit was reported; the forecaster's own chance of this, stated with the estimate: 45%; the middle value does not contradict the limit.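

In this assay compound 4 gives only a limit, not a number: the limit of > 25000 nM in this assay, at which 1 of the 4 values shown sits. With 1-hydroxycyclohexyl in place of hydroxymethyl on a triple-bonded carbon, the series shows an at least 2.4-fold higher number from compound 1 to compound 4 (0.39 log units; beyond the scatter), which extends the higher numbers seen against the hydroxymethyl compound to a group carrying a six-membered non-aromatic ring of carbon only. The steps to compound 4 from compound 2 and from compound 3 cannot be read, and the order among the 1-hydroxyethyl, 2-hydroxybutyl and 1-hydroxycyclohexyl groups stays undecided.

The compounds shown leave open how an amine or a methoxy group in place of the hydroxy on this alkyne chain would read in this assay. Placing compound 4 against compound 2 and compound 3 would take a number rather than a limit.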